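Cytotoxicity of three amide variants and a fourth

This account rests on a few compounds, and the source may have more. Where it says the series, first, only, none or still open, it means among the compounds named here.

Compound 1 `CC(Cl)CC(=O)NC1=C(C#N)C(c2ccc(Cl)cc2Cl)C2=C(CCCC2=O)N1c1ccc(S(N)(=O)=O)cc1`: 50%
Compound 2 `N#CC1=C(NC(=O)C2CC2)N(c2ccc(S(N)(=O)=O)cc2)C2=C(C(=O)CCC2)C1c1ccc(Cl)cc1Cl`: 40%
Compound 3 `COc1cc(C(=O)NC2=C(C#N)C(c3ccc(Cl)cc3Cl)C3=C(CCCC3=O)N2c2ccc(S(N)(=O)=O)cc2)cc(OC)c1OC`: 20%

Of the compounds shown here, three sharing one core have been tested in a functional assay on Ehrlich cells (Mus musculus) for cytotoxicity, read by trypan blue exclusion, with a stated time of 2 h, tested at 25 ug/mL; on this read-out lower numbers stand for a weaker effect and higher numbers for a stronger effect at the one concentration tested. They differ only in the group attached to the carbonyl carbon of the amide. In this assay compound 1 gives 50%, compound 2 gives 40%, and compound 3 gives 20%, which puts compound 3 at the bottom of the three. The step of a number 30 percentage points lower from compound 1 to compound 3 (beyond the scatter) and the step of a number 20 percentage points lower from compound 2 to compound 3 (beyond the scatter) both lie beyond the scatter, whereas a number 10 percentage points lower from compound 1 to compound 2 (within the scatter) does not.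

Compound 4 `CC(=O)CC(=O)NC1=C(C#N)C(c2ccc(Cl)cc2Cl)C2=C(CCCC2=O)N1c1ccc(S(N)(=O)=O)cc1` has not yet been measured. It differs from compound 3 as follows: 2-oxopropyl in place of 3,4,5-trimethoxyphenyl on a carbonyl carbon. The change therefore replaces the aromatic ring by a short chain, so compound 4 resembles compound 1 and compound 2 more than compound 3. The two steps that end at compound 3 are the relevant ones: leaving the 3,4,5-trimethoxyphenyl group is expected to undo the drop seen in a number 30 percentage points lower from compound 1 to compound 3 (beyond the scatter). In this assay compound 4 is therefore expected to reach 45%, within a range from 30% to 60%, an estimated rise a number 25 percentage points higher from compound 3 to compound 4 (beyond the scatter).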

Compound 4, a percentage reported as activity, at one concentration (the size of the read-out at that concentration, not a potency): 44%
Compound 4: middle estimate off by 1 percentage points, on the high side; measured number inside the range.
By their numbers in this assay, from the lowest: compound 3; then compounds 2, 4 and 1 (each within the scatter of the next).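

In this assay, replacing the 3,4,5-trimethoxyphenyl group with 2-oxopropyl on the amide carbonyl carbon gives a number 24 percentage points higher from compound 3 to compound 4 (beyond the scatter), so the low number of compound 3 does not carry over to this short chain. The new group also sits level with the other two non-aromatic groups, with a number 4 percentage points higher from compound 2 to compound 4 (within the scatter) and a number 6 percentage points lower from compound 1 to compound 4 (within the scatter), so among these four compounds only the one bearing an aromatic ring stands apart, and the 2-chloropropyl, cyclopropyl and 2-oxopropyl groups cannot be told apart here. Nothing shown explains why the number changes with this swap.

On these data alone, it remains open whether the low number of compound 3 goes with the aromatic ring itself or with its methoxy groups, a question that an unsubstituted phenyl group could address. As far as these compounds go, how far the position tolerates other non-aromatic groups, such as a longer chain or one ending in an amine, also remains open.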